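The compounds below may be only part of what the source reports. "The series", "measured", "known", "first", "only" and "open" are said of these compounds alone.

Of the compounds shown here, three built on one shared core have been tested in a toxicity assay on MDCK cells (Canis lupus familiaris) for cytotoxicity, read by crystal violet staining, with a stated time of 48 h; on this read-out higher numbers stand for lower toxicity in this test and lower numbers for higher toxicity in this test. Compound 1 `COc1ccc(CN(Cc2ccc(C(C)(C)C)cc2)Cc2cc3cc(C)ccc3[nH]c2=O)cc1` gives > 10000 nM, which is a limit of the assay rather than a number. Compound 2 `CCOc1ccc(CN(Cc2ccc(C(C)(C)C)cc2)Cc2cc3cc(C)ccc3[nH]c2=O)cc1` gives > 10000 nM, also a limit. Compound 3 `Cc1ccc2[nH]c(=O)c(CN(Cc3ccc(OCCO)cc3)Cc3ccc(C(C)(C)C)cc3)cc2c1` gives > 5000 nM, again a limit, so compound 3 stands where the whole set stands, with no number to place it against the others. The measured steps, a step that the two limits leave unreadable from compound 1 to compound 2, a step that the two limits leave unreadable from compound 1 to compound 3 and a step that the two limits leave unreadable from compound 2 to compound 3, therefore carry no readable size. Compound 4 `Cc1ccc2[nH]c(=O)c(CN(Cc3ccc(SC(F)(F)F)cc3)Cc3ccc(C(C)(C)C)cc3)cc2c1` has not yet been measured; it differs from compound 3 by (trifluoromethyl)sulfanyl in place of 2-hydroxyethoxy on an aromatic carbon. For the measured compounds named here, no measured step gives a readable size or direction for this change. Compound 4 is expected to sit near 12000 nM, within 4000 nM to 40000 nM, most likely again as a limit. The expected step that the limit leaves unreadable from compound 3 to compound 4 is estimated to stay within the scatter.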

Compound 4, half-maximal cytotoxic concentration: > 5000 nM
Compound 4: no number, only a limit; the forecaster's own chance of this, stated with the estimate: 75%; the middle value lies beyond the limit too.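

For the compounds shown here, compound 4 gives > 5000 nM as a limit of the assay, not a number, so no step to it from compound 1, compound 2 or compound 3 can be read. The compounds shown leave open whether any of the four differs from another in cytotoxicity.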